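The source may report more compounds than this note shows. Statements on the series, on what has been measured and on what is new or still open speak of the compounds shown alone.

Measured so far in a functional assay on QG-56 cells (Homo sapiens) for cytotoxicity, read by MTT assay, with a stated time of 48 h (on this read-out lower numbers stand for stronger inhibition and higher numbers for weaker inhibition), are three compounds:
- compound 1 `COc1cc(/C=C/C(=O)C2=C(/C=C/c3ccc(O)c(OC)c3)NC(=S)NC2c2ccccc2)ccc1O` gives 100000 nM
- compound 2 `COc1cc(/C=C/C(=O)C2=C(/C=C/c3ccc(O)c(OC)c3)NC(=S)NC2c2ccc(C)cc2)ccc1O` gives 12500 nM
- compound 3 `COc1cc(/C=C/C(=O)C2=C(/C=C/c3ccc(O)c(OC)c3)NC(=S)NC2c2c(Cl)cccc2Cl)ccc1O` gives 100000 nM

Compound 3 shares the highest number of the three with compound 1, so only compound 2 stands clearly apart from it (an 8.0-fold higher number from compound 2 to compound 3 (0.90 log units; beyond the scatter)). The next compound, compound 4 `COc1cc(/C=C/C(=O)C2=C(/C=C/c3ccc(O)c(OC)c3)NC(=S)NC2c2ccccc2Cl)ccc1O`, keeps the shared core and differs in one place: hydrogen in place of chloro on an aromatic carbon, which turns 2,6-dichlorophenyl into 2-chlorophenyl (hydrogen in place of chloro on an aromatic carbon).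

The closest evidence is the comparison of the unsubstituted phenyl with the 2,6-dichlorophenyl (no change at the digits printed from compound 1 to compound 3 (within the scatter)). Compound 4 carries one chloro group, compound 1 carries none and compound 3 carries two, and those two end points do not differ. Among the compounds with values here, no compound with a single chloro group has been measured, however. The methyl step (an 8.0-fold lower number from compound 1 to compound 2 (0.90 log units; beyond the scatter)) also shows that a small change on this ring can move the number, so a larger drop cannot be ruled out.

In this assay the expected move is a 1.7-fold lower number from compound 3 to compound 4 (0.22 log units; within the scatter) and so no step beyond the scatter. The expected value for compound 4 is 60000 nM within an estimated range from 15000 nM to 120000 nM on this read-out.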

Compound 4, half-maximal inhibitory concentration: 50000 nM
Compound 4: middle estimate off by 1.2-fold (0.08 log units), on the high side; the range from low to high includes it.
By their numbers in this assay, from the lowest: compound 2; then compounds 4, 1 and 3 (each within the scatter of the next).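

In this assay, the 2-chlorophenyl fills the gap between the two earlier end points: taking one chloro group off the 2,6-dichlorophenyl gives a 2.0-fold lower number from compound 3 to compound 4 (0.30 log units; within the scatter), and adding one to the unsubstituted phenyl gives a 2.0-fold lower number from compound 1 to compound 4 (0.30 log units; within the scatter), so rings with none, one or two chloro groups cannot be told apart in these compounds. The 4-methylphenyl stays clearly apart from the new compound, with a 4.0-fold higher number from compound 2 to compound 4 (0.60 log units; beyond the scatter), which leaves it as the only ring among the four that stands out from the others. Nothing measured here explains why these rings read as they do.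

The compounds shown leave open whether the step seen with methyl belongs to that group alone or would also appear with a longer chain such as ethyl, or with a methoxy group, an amine or a carboxylic acid on the ring. They also leave open whether a 4-chlorophenyl would read like the 4-methylphenyl or like the 2-chlorophenyl.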